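Methyl on the Ring Nitrogen Neighbour: Three Analogues, One Projection

The source may report more compounds than this note shows. Statements on the series, on what has been measured and on what is new or still open speak of the compounds shown alone.

Measured compounds:
Compound 1, `Cc1cc(-c2nn3c(-c4ccoc4C)nnc3s2)c2ccccc2n1`, 13.4%
Compound 2, `Cc1occc1-c1nnc2sc(-c3ccnc4ccccc34)nn12`, 17.1%
Compound 3, `COc1ccc(Cl)c(-c2nnc3sc(Cc4c[nH]c5ccc(OC)cc45)nn23)c1`, 14.4%

All three were tested in a functional assay on the whole organism (strain Wistar Albino) for inhibition, with Rattus norvegicus as the target, read by paw edema, with a stated time of 2 h, at a dose of 20 mg/kg; on this read-out lower numbers stand for less inhibition and higher numbers for more inhibition at the one dose given (going by the name of the read-out). Going by the values given here, compound 2 gives 17.1% and compound 1 gives 13.4%; the step of a number 3.7 percentage points lower from compound 2 to compound 1 (within the scatter) is the only pairwise change counted among the measured compounds, and it rests on (methyl in place of hydrogen on an aromatic carbon). Compound 3 gives 14.4%; its gaps to compound 1 and to compound 2 both fall within the scatter, so no order among the three is claimed. The difference between the core of compound 3 and the core of compound 2 is not broken down here.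

Compound 4, `COc1ccc(Cl)c(-c2nnc3sc(Cc4c(C)[nH]c5ccc(OC)cc45)nn23)c1`, is not yet measured in this assay. It differs from compound 3 by methyl in place of hydrogen on an aromatic carbon. Among the compounds with values here, this is the same kind of change as the one from compound 2 to compound 1, not the same change: in compound 1 the methyl enters on a six-membered aromatic ring, meta to a fused ring, meta to a large group and para to a fused ring, whereas in compound 4 it enters on a five-membered aromatic ring, next to the ring atom that bears a large group.

Within the data shown here, the only counted precedent, a number 3.7 percentage points lower from compound 2 to compound 1 (within the scatter), lies within the scatter, so a step of similar size is expected for compound 4: a number 2.4 percentage points lower from compound 3 to compound 4 (within the scatter). Compound 4 is accordingly estimated at 12% in this assay, with an expected range from 4% to 22%, resting on a single precedent and a different ring.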

Compound 4, a percentage reported as inhibition, in the whole organism at one dose (the size of the read-out at that dose, not a potency): 20%
Estimate against measurement, compound 4: 8 percentage points below; measured number inside the range.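

In this assay, methyl in place of hydrogen on an aromatic carbon now has a second reading, on the five-membered aromatic ring of compound 4: a number 5.6 percentage points higher from compound 3 to compound 4 (within the scatter). Set beside the earlier reading on a six-membered aromatic ring, this step cannot be told apart from it: the same change on two cores in this assay, a number 3.7 percentage points lower (within the scatter) from compound 2 to compound 1 and a number 5.6 percentage points higher (within the scatter) from compound 3 to compound 4, 9.3 percentage points apart, within the scatter of two such steps. This gives no sign that the outcome of the change depends on the core in these two pairs, but each step lies within the scatter, so it does not show that methyl has an effect on either core, that the opposite directions of the two steps are real, or that the change carries over reliably to other cores in the series.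

The compounds shown cover only hydrogen and methyl on this carbon of the core of compound 3, so the outcome with a longer chain, a chlorine atom or an amine there remains open. Going by these compounds, every number also comes from the one dose and the one stated time, so whether the compounds would separate at other doses or times remains open as well.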